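Compound 4 and the Aryl Exchange in Dopamine Receptor Binding

A few compounds are considered here, and "the series" means these few. Any claim that something is new, unique, unknown or untested is made for them only; others in the source may bear on it.

Three measured compounds share one core and differ only in the aryl group sitting on a saturated chain carbon bound to a nitrogen on an aromatic ring. Compound 1 `COc1ccccc1N1CCN(CCCNC(=O)NN(Cc2ccccc2F)c2ccc(F)cc2)CC1` gives 3.6 nM in an assay on CHO cells for displacement of a labelled ligand from D(4) dopamine receptor (Homo sapiens), read by radioligand binding; a lower number here means a stronger inhibitor, a higher number a weaker inhibitor. Compound 2 `COc1ccccc1N1CCN(CCCNC(=O)NN(Cc2ccc(F)cc2)c2ccc(F)cc2)CC1` gives 4.6 nM in this assay. Compound 3 `COc1cccc(CN(NC(=O)NCCCN2CCN(c3ccccc3OC)CC2)c2ccc(F)cc2)c1` gives 5.9 nM in this assay, the highest number of the three, though a 1.6-fold higher number from compound 1 to compound 3 (0.21 log units; within the scatter) and a 1.3-fold higher number from compound 2 to compound 3 (0.11 log units; within the scatter) both lie within the scatter, as does a 1.3-fold higher number from compound 1 to compound 2 (0.11 log units; within the scatter). Among these three, exchanging one substituted phenyl for another at that carbon produced nothing beyond the scatter.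

Compound 4 `COc1ccccc1N1CCN(CCCNC(=O)NN(Cc2ccc(-c3ccccc3)cc2)c2ccc(F)cc2)CC1` has not yet been measured. It differs from compound 3 in this way: 4-phenylphenyl in place of 3-methoxyphenyl on a saturated chain carbon bound to a nitrogen on an aromatic ring. All three measured steps bear on this change. Each also exchanges the aryl group at the same place, and each remained within the scatter. None of them, however, introduces a 4-phenylphenyl, so the measured steps cover a narrower kind of exchange than the one at hand. The author therefore expects a 1.2-fold higher number from compound 3 to compound 4 (0.07 log units; within the scatter) in this assay, a step not beyond the scatter, with the range widened for the untested group. For compound 4 the estimate in this assay is 7 nM, between 2.5 nM and 25 nM.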

Compound 4, inhibition constant: 5.9 nM
Compound 4: the middle estimate sits 1.2-fold (0.07 log units) above what was measured, and the stated range covers the measured number.
By their numbers in this assay, from the lowest: compounds 1, 2, 3 and 4 (each within the scatter of the next).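

In this assay, the position on a saturated chain carbon bound to a nitrogen on an aromatic ring accepted 4-phenylphenyl, with 2 six-membered aromatic rings of carbon only, in place of 3-methoxyphenyl, with one such ring, and the step reads no change at the digits printed from compound 3 to compound 4 (within the scatter). The two other comparisons agree: phenyl in place of fluoro on an aromatic carbon gives a 1.3-fold higher number from compound 2 to compound 4 (0.11 log units; within the scatter), and 4-phenylphenyl in place of 2-fluorophenyl gives a 1.6-fold higher number from compound 1 to compound 4 (0.21 log units; within the scatter). The earlier compounds showed only exchanges among groups with one aromatic ring, whereas these steps extend the flat picture to a group with a second ring and no hydrogen-bond acceptor, though nothing available here accounts for this flatness.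

The compounds shown leave open whether an aryl group carrying an amine or a carboxylic acid, or a longer chain in place of the aryl group, would also stay within the scatter at this position. They also leave open whether the same exchanges would read as flat if the rest of the shared core were altered, since it stays constant across compounds 1 to 4.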